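Methoxy in place of methyl on the shared core

A few compounds are considered here, and "the series" means these few. Any claim that something is new, unique, unknown or untested is made for them only; others in the source may bear on it.

compound 1 `CCOC(=O)c1sc2ccccc2c1Nc1cc(OC)c(OC)c(OC)c1`: 3020 nM
compound 2 `CCOC(=O)c1sc2cc(C)ccc2c1Nc1cc(OC)c(OC)c(OC)c1`: 0.4 nM

In a functional assay on Jurkat cells (Homo sapiens) for cytotoxicity, read by MTT assay, with a stated time of 72 h (a higher number here means a weaker inhibitor, a lower number a stronger inhibitor), compound 2 holds the lower of the two numbers at 0.4 nM. Compound 3 `CCOC(=O)c1sc2cc(OC)ccc2c1Nc1cc(OC)c(OC)c(OC)c1` carries methoxy in place of methyl on an aromatic carbon. Within the data shown here, the one measured step at this carbon, a 7600-fold lower number from compound 1 to compound 2 (3.88 log units; beyond the scatter), was large and beyond the scatter, and it came from methyl in place of hydrogen. Among the measured compounds shown here, no measured compound carries methoxy at this carbon, so that step gives only indirect guidance. A return to the level of compound 1 at 3020 nM is not expected, since compound 3 still has a group at this carbon. A moderate rise in this assay is expected, with real uncertainty about its direction. The estimated step is a 5.0-fold higher number from compound 2 to compound 3 (0.70 log units; beyond the scatter). For compound 3 the expected value is 2 nM, with an estimated range of 0.1 nM to 60 nM.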

Compound 3, half-maximal inhibitory concentration: 3.3 nM
Estimate against measurement, compound 3: 1.7-fold (0.22 log units) below; low and high end bracket the measured number.
By their numbers in this assay, from the lowest: compound 2; then compound 3; then compound 1.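

In this assay, the gain over hydrogen on the shared core is not unique to methyl: methoxy in place of hydrogen at this aromatic carbon gives a 920-fold lower number from compound 1 to compound 3 (2.96 log units; beyond the scatter) and so also yields a far lower number. The two groups are still not interchangeable, since methoxy in place of methyl gives an 8.3-fold higher number from compound 2 to compound 3 (0.92 log units; beyond the scatter) and methyl remains the better of the two at this carbon. No measurement at hand accounts for either step.

With only hydrogen, methyl and methoxy shown at this carbon, it remains open whether ethoxy, a chlorine atom or an amine would stay near compound 2 or fall back toward compound 1. Also open, from the compounds shown here alone, is whether the order of these groups would hold at the other aromatic carbons of the shared core.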